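Bicyclic heteroaryl replacement at the urea-linked phenyl

The source may hold more compounds than are shown below. What is called first, only, known or untested is meant among the compounds shown, and "the series" means these compounds.

Measured so far in a functional assay on MV4-11 cells (Homo sapiens) for cytotoxicity, read by MTT assay, with a stated time of 72 h; on this read-out higher numbers stand for weaker inhibition and lower numbers for stronger inhibition:
compound 1 `CC(C)(C)c1cc(NC(=O)Nc2ccc(-c3cn4ncccc4n3)cc2)no1`: 59.1 nM
compound 2 `CC(C)(C)c1cc(NC(=O)Nc2ccc(-c3cc4ccccc4o3)cc2)no1`: 195 nM

Compound 2 holds the highest number of the two measured in this assay; its nearest neighbour is compound 1, and the step of a 3.3-fold higher number from compound 1 to compound 2 (0.52 log units; beyond the scatter) is the only one recorded in the series. Compound 3 `CC(C)(C)c1cc(NC(=O)Nc2ccc(-c3nc4ccccc4o3)cc2)no1` is not yet measured. It differs from compound 2 by 1,3-benzoxazol-2-yl in place of 1-benzofuran-2-yl on an aromatic carbon. Going by the values given here, the one step that bears on this change is a 3.3-fold higher number from compound 1 to compound 2 (0.52 log units; beyond the scatter), where a bicycle with more heteroatoms gave the lower number; the present change again adds a heteroatom to the five-membered ring, though the six-membered ring stays carbon only, so only part of that step is a guide. A modest step in the same direction, down from compound 2 and not necessarily beyond the scatter, is therefore expected: a 1.8-fold lower number from compound 2 to compound 3 (0.25 log units; within the scatter). Compound 3 is estimated at 110 nM, with a range of 40 nM to 300 nM.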

Compound 3, half-maximal inhibitory concentration: 82.6 nM
Compound 3: middle estimate off by 1.3-fold (0.12 log units), on the high side; low and high end bracket the measured number.
By their numbers in this assay, from the lowest: compounds 1 and 3 (each within the scatter of the next); then compound 2.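

In this assay, a change confined to the five-membered ring, with a ring nitrogen entering the 1-benzofuran-2-yl group to give 1,3-benzoxazol-2-yl, is enough for a step beyond the scatter (a 2.4-fold lower number from compound 2 to compound 3 (0.37 log units; beyond the scatter)). Hetero atoms in the six-membered ring are not needed to reach the range of compound 1, since that ring is carbon only in compound 3 and the two compounds cannot be told apart (a 1.4-fold higher number from compound 1 to compound 3 (0.15 log units; within the scatter)). No supporting data are available to account for what the added ring nitrogen does here.

Open, going by these compounds, is whether a single ring, such as pyridin-2-yl, can stand in for the bicycle at this position. Also open, on these data alone, is how a methoxy or aminomethyl group on the six-membered ring of the 1,3-benzoxazol-2-yl group would move the number.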